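The compounds below may be only part of what the source reports. "The series", "measured", "known", "first", "only" and "open" are said of these compounds alone.

Measured so far in a functional assay on A549 cells (Homo sapiens) for inhibition, read by CCK-8 assay, with a stated time of 72 h, tested at 10 uM; on this read-out lower numbers stand for less inhibition of growth and higher numbers for more inhibition of growth at the one concentration tested:

compound 1 `CN(C)C(=O)c1cc2cnc(Nc3ccc(NC(=O)C4(C(=O)Nc5ccc(Br)cc5)CC4)cc3)nc2n1C1CCCC1` gives 90.3%
compound 2 `CN(C)C(=O)c1cc2cnc(Nc3ccc(NC(=O)C4(C(=O)Nc5ccc(Cl)c(C(F)(F)F)c5)CC4)cc3)nc2n1C1CCCC1` gives 88.1%
compound 3 `COC(=O)c1cccc(NC(=O)C2(C(=O)Nc3ccc(Nc4ncc5cc(C(=O)N(C)C)n(C6CCCC6)c5n4)cc3)CC2)c1` gives 91%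

Compound 3 sits level with compound 1 and compound 2, as a number 0.7 percentage points higher from compound 1 to compound 3 (within the scatter) and a number 2.9 percentage points higher from compound 2 to compound 3 (within the scatter) are both small. Compound 4 `CN(C)C(=O)c1cc2cnc(Nc3ccc(NC(=O)C4(C(=O)Nc5cccc(C(F)(F)F)c5)CC4)cc3)nc2n1C1CCCC1` has trifluoromethyl in place of methoxycarbonyl on an aromatic carbon, meta to a large group (trifluoromethyl in place of methoxycarbonyl on an aromatic carbon). Compound 2 also carries a trifluoromethyl group, which makes a number 2.9 percentage points higher from compound 2 to compound 3 (within the scatter) the closest guide. Swapping this aryl group has moved the number little so far, as a number 2.2 percentage points lower from compound 1 to compound 2 (within the scatter) also shows. No change beyond the scatter is therefore expected, and the estimated step is a number 2 percentage points lower from compound 3 to compound 4 (within the scatter) in this assay. Compound 4 is expected at 89%, with an estimated range of 81% to 95% here.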

Compound 4, percent growth inhibition at one concentration: 89.2%
Compound 4: the middle estimate sits 0.2 percentage points below what was measured; measured number inside the range.
By their numbers in this assay, from the lowest: compounds 2, 4, 1 and 3 (each within the scatter of the next).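

In this assay, trifluoromethyl in place of methoxycarbonyl on this aromatic carbon gives a number 1.8 percentage points lower from compound 3 to compound 4 (within the scatter), so losing the hydrogen-bond acceptors of the ester group leaves the number level. Hydrogen in place of chloro gives a number 1.1 percentage points higher from compound 2 to compound 4 (within the scatter), and 3-(trifluoromethyl)phenyl in place of 4-bromophenyl gives a number 1.1 percentage points lower from compound 1 to compound 4 (within the scatter), so neither the chloro group nor the choice of aryl group shown here moves the number beyond the scatter. Nothing measured here explains why these steps stay small. On these data alone, whether an amine or a carboxylic acid on this ring would also leave the number level stays open. So does whether these four compounds would separate at lower concentrations.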